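Ethyl for Methyl on a Thiophene Amide Series

The source may hold more compounds than are shown below. What is called first, only, known or untested is meant among the compounds shown, and "the series" means these compounds.

Measured compounds:
- compound 1, `CCc1ccc(NC(=O)CN2CCN(c3ccc(F)cc3)CC2)cc1`, 2500 nM
- compound 2, `CCCc1cc(C(=O)OCC)c(NC(=O)C2CCN(C(C)=O)CC2)s1`, 5900 nM
- compound 3, `COC(=O)c1cc(C)sc1NC(=O)C1CCN(C(C)=O)CC1`, 9400 nM

All three were tested in an assay for displacement of a labelled ligand from DNA repair protein REV1 (Homo sapiens), read by fluorescence polarization, with a stated time of 1 h; a higher number here means a weaker inhibitor, a lower number a stronger inhibitor. Compound 3 gives 9400 nM, the highest of the three numbers. Compound 1 gives 2500 nM, a lower number than compound 3 by a gap beyond the usual scatter, so compound 1 is the stronger inhibitor of that pair. Compound 2 gives 5900 nM, and the gap between compound 2 and compound 3 lies within the scatter, so those two cannot be told apart on this evidence.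

Compound 4, `CCc1cc(C(=O)OC)c(NC(=O)C2CCN(C(C)=O)CC2)s1`, has not yet been measured. It differs from compound 3 by methyl in place of hydrogen on a saturated chain carbon bound to an aromatic carbon, which turns the methyl on the core into an ethyl. Going by the values given here, no measured pair shows this step alone, and compound 2 carries both a longer chain and a different ester, so it offers only a loose guide. The change is small, and the step from compound 3 to compound 4 in this assay is expected to be a 1.3-fold lower number from compound 3 to compound 4 (0.10 log units; within the scatter), that is, no change beyond the scatter. For compound 4 the expected value is 7500 nM, with a range from 3000 nM to 20000 nM.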

Compound 4, half-maximal inhibitory concentration: 12400 nM
Beside the measured number, compound 4's estimate is 1.7-fold (0.22 log units) below it; the range from low to high includes it.
By their numbers in this assay, from the lowest: compound 1; then compounds 2, 3 and 4 (each within the scatter of the next, the first and the last beyond it).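

Turning the methyl on the core into an ethyl gives a 1.3-fold higher number from compound 3 to compound 4 (0.12 log units; within the scatter) in this assay and this is the first pair here that differs in one place only, so it isolates the effect of this step. The position accepts this one extra carbon with no change that can be told from the spread of repeated measurements, something compound 2 could not show, as it differs from compound 3 in both its chain and its ester. No evidence on hand explains this result.

A single small step at one position does not show how a longer chain, such as propyl, would behave with the methyl ester kept, or what the ester contributes when the chain stays fixed. It also leaves open whether an amine or a carboxylic acid at the end of the chain, on this saturated chain carbon bound to an aromatic carbon, would shift the number beyond the scatter.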